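A trifluoromethyl swap on compound 3

This account rests on a few compounds, and the source may have more. Where it says the series, first, only, none or still open, it means among the compounds named here.

In an ADME assay on MT4 cells (Homo sapiens) for cytotoxicity, read by MTT assay, with a stated time of 3 days (a higher number here means that more compound is tolerated, a lower number that less compound is tolerated), compound 3 `CC(=O)Oc1ccccc1CN(C(=O)COC(=O)c1ccc([N+](=O)[O-])o1)C(C)(C)C` gives > 100000 nM, which is a limit of the assay and not a number. Compound 2 `CC(C)(C)N(Cc1cccc([N+](=O)[O-])c1)C(=O)COC(=O)c1ccc([N+](=O)[O-])o1` gives > 100000 nM, which is also a limit. Compound 1 `CC(C)(C)N(CCC(=O)c1ccccc1)C(=O)COC(=O)c1ccc([N+](=O)[O-])o1` is reported as "not active" (no number reported), with no number attached.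

Compound 4 `CC(C)(C)N(Cc1cccc(C(F)(F)F)c1)C(=O)COC(=O)c1ccc([N+](=O)[O-])o1` has not been measured yet. It carries 3-(trifluoromethyl)phenyl in place of 2-acetoxyphenyl on a saturated chain carbon bound to an amide-type nitrogen.

Going by the values given here, only one measured step bears on this change, a step that the two limits leave unreadable from compound 2 to compound 3, and its size cannot be read. The best guide is therefore (the limit of > 100000 nM in this assay, at which 2 of the 3 values shown sit). No step beyond the usual scatter is expected in this assay, and no direction can be argued from these data. The expected step is a number no higher from compound 3 to compound 4 (the limit leaves the size open). The estimate for compound 4 is 100000 nM, with an expected range of 30000 nM to 200000 nM. The assay may well report only a limit again.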

Compound 4, half-maximal cytotoxic concentration: > 100000 nM
Compound 4: only a limit was reported (the forecaster's own chance of this, stated with the estimate: 75%); the middle value lies on the limit itself.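

Compound 4 returns only a limit of the assay and not a number, as do compound 2 and compound 3, so no step among these three compounds can be read. The compounds shown leave open how much of each one the cells actually tolerate, and whether these group swaps change that amount at all.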